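This account rests on a few compounds, and the source may have more. Where it says the series, first, only, none or still open, it means among the compounds named here.

In an ADME assay on NHDF cells (Homo sapiens) for cytotoxicity, read by MTT assay, with a stated time of 72 h (a higher number here means a weaker inhibitor, a lower number a stronger inhibitor), compound 1 `COc1cccc(/C=C2\CCC/C(=C\c3ccccc3Br)C2=O)c1OC` reaches only a limit of the assay, > 50000 nM. For the measured compounds named here, compound 2 `COc1cccc(/C=C2\CCC/C(=C\c3ccc(Cl)cc3Cl)C2=O)c1OC` gives 49200 nM, the only actual number so far. Going by the values given here, the one measured step is an at least 1.0-fold lower number from compound 1 to compound 2 (0.00 log units; that floor lies within the scatter), and it shows no clear direction. Compound 3 `COc1cccc(/C=C2\CCC/C(=C\c3ccc(O)c(O)c3)C2=O)c1OC`, not yet measured, carries 3,4-dihydroxyphenyl in place of 2,4-dichlorophenyl (3,4-dihydroxyphenyl in place of 2,4-dichlorophenyl on a double-bonded chain carbon bound to a double-bonded ring carbon). Among the compounds with values here, with an at least 1.0-fold lower number from compound 1 to compound 2 (0.00 log units; that floor lies within the scatter) as the only guide, no change beyond the scatter is expected, and the expected step is a 1.6-fold lower number from compound 2 to compound 3 (0.21 log units; within the scatter). For compound 3 the estimated value is 30000 nM, with an expected range of 8000 nM to 50000 nM.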

Compound 3, half-maximal inhibitory concentration: 17900 nM
For compound 3 the middle estimate is 1.7-fold (0.22 log units) above the measured one; the range from low to high includes it.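

In this assay, the place on a double-bonded chain carbon bound to a double-bonded ring carbon now shows a change beyond the scatter, as 3,4-dihydroxyphenyl replaces 2,4-dichlorophenyl: a 2.7-fold lower number from compound 2 to compound 3 (0.44 log units; beyond the scatter). Compound 1 gives only a limit, not a number: the limit of > 50000 nM in this assay, at which 1 of the 3 values shown sits. The change from 2-bromophenyl to 3,4-dihydroxyphenyl can therefore be read only as a floor: an at least 2.7-fold lower number from compound 1 to compound 3 (0.44 log units; beyond the scatter).

On these data alone, it remains open whether the lower number needs both hydroxyl groups or only one. How an amine or a carboxylic acid on this ring would read is also unknown.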